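The source may report more compounds than this note shows. Statements on the series, on what has been measured and on what is new or still open speak of the compounds shown alone.

Compound 1 `CCN(Cc1ccncc1)C(=S)SCc1ccc(C(=O)Nc2ccccc2N)cc1` carries an ethyl((pyridin-4-yl)methyl)amino group on its thiocarbonyl carbon. In a functional assay on A-375 cells (Homo sapiens) for antiproliferative activity, read by CCK-8 assay, with a stated time of 72 h, tested at 2 uM (on this read-out lower numbers stand for a weaker effect and higher numbers for a stronger effect at the one concentration tested), compound 1 gives 67.2%, the highest of the three numbers in hand. Compound 2 `Nc1ccccc1NC(=O)c1ccc(CSC(=S)N2CCN(c3ccccc3F)CC2)cc1` gives 18.7% and compound 3 `Nc1ccccc1NC(=O)c1ccc(CSC(=S)N2CCN(c3ncccn3)CC2)cc1` gives 24%; both carry a different amine on the thiocarbonyl carbon, and a number 5.3 percentage points higher from compound 2 to compound 3 (within the scatter). Compound 4 `Nc1ccccc1NC(=O)c1ccc(CSC(=S)N2CCc3ccccc32)cc1` differs from compound 1 in one place: 2,3-dihydro-1H-indol-1-yl in place of ethyl((pyridin-4-yl)methyl)amino on a thiocarbonyl carbon. Among the measured compounds shown here, no measured step covers this exact change, and the only measured step touches another position and stayed within the scatter. Compounds 2 and 3 both stand far under compound 1, so a downward step is expected, a number 32.2 percentage points lower from compound 1 to compound 4 (beyond the scatter). Compound 4 is therefore estimated at 35%, within 15% to 60%.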

Compound 4, a percentage reported as inhibition, at one concentration (the size of the read-out at that concentration, not a potency): 25.7%
Compound 4: the middle estimate sits 9.3 percentage points above what was measured, within the range that was stated.
By their numbers in this assay, from the lowest: compounds 2, 3 and 4 (each within the scatter of the next); then compound 1.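

In this assay, putting 2,3-dihydro-1H-indol-1-yl in place of ethyl((pyridin-4-yl)methyl)amino on the thiocarbonyl carbon gives a number 41.5 percentage points lower from compound 1 to compound 4 (beyond the scatter). Among the compounds shown here, this is the first single-place change at this position, and it shows that the group held there can move the read-out well past the scatter. No measurement here accounts for the drop.

Still open, from the compounds shown here alone, is which part of the departing group matters, the ring nitrogen of the pyridin-4-yl or the open ethyl chain. Benzyl(ethyl)amino or diethylamino on the same carbon would help separate the two.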